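This account rests on a few compounds, and the source may have more. Where it says the series, first, only, none or still open, it means among the compounds named here.

Measured compounds:
compound 1 `O=c1[nH]cnc2c1c(-c1ccoc1)cn2[C@@H]1O[C@H](CO)[C@@H](O)[C@H]1O` — > 20000 nM
compound 2 `O=c1[nH]cnc2c1c(-c1cccs1)cn2[C@@H]1O[C@H](CO)[C@@H](O)[C@H]1O` — > 20000 nM
compound 3 `Nc1nc(N)c2c(-c3cccs3)cn([C@@H]3O[C@H](CO)[C@@H](O)[C@H]3O)c2n1` — > 20000 nM

In a functional assay on A549 cells (Homo sapiens), read by MTT assay, with a stated time of 72 h (a higher number here means a weaker inhibitor, a lower number a stronger inhibitor), compound 1 gives > 20000 nM, which is a limit of the assay and not a number. Compound 2 likewise gives > 20000 nM, again a limit. Compound 3 gives > 20000 nM, also a limit. The change from compound 2 to compound 1 is furan-3-yl in place of thiophen-2-yl on an aromatic carbon; the step it made is a step that the two limits leave unreadable from compound 2 to compound 1. How the core of compound 3 differs from the core of compound 2 is not broken down here.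

Compound 4 `Nc1nc(N)c2c(-c3ccoc3)cn([C@@H]3O[C@H](CO)[C@@H](O)[C@H]3O)c2n1` has not yet been measured. It differs from compound 3 by furan-3-yl in place of thiophen-2-yl on an aromatic carbon, the same change that was made from compound 2 to compound 1. Because of the limit of > 20000 nM in this assay, at which 3 of the 3 values shown sit, that earlier step gives no readable size, and the same change on the core of compound 3 offers no basis for expecting a readable number either. The step expected from compound 3 to compound 4 is a step that the limit leaves unreadable from compound 3 to compound 4, resting on the fact that compound 3 sits at > 20000 nM, and on the unreadable step that the two limits leave unreadable from compound 2 to compound 1. Compound 4 is therefore expected in this assay to come out around 40000 nM, most probably reported again only as a limit, with a range estimated from 15000 nM to 150000 nM.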

Compound 4, half-maximal inhibitory concentration: > 20000 nM
Compound 4 ended at the assay's limit; the forecaster's own chance of this, stated with the estimate: 85%; the middle value does not contradict the limit.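

No step can be read from compound 3 to compound 4, because in this assay both compounds stand at a limit of the assay and not at a number: the limit of > 20000 nM in this assay, at which 4 of the 4 values shown sit.

The compounds shown leave open how far any of them lies beyond that limit, and whether furan-3-yl in place of thiophen-2-yl changes activity on either core.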